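The source may report more compounds than this note shows. Statements on the series, on what has been measured and on what is new or still open speak of the compounds shown alone.

Compound 1 `COc1cc(-c2nc3cc(/C=C4\SC(=O)NC4=O)ccc3[nH]2)cc(OC)c1OC` and compound 2 `COc1ccc(-c2nc3cc(/C=C4\SC(=O)NC4=O)ccc3[nH]2)cc1OC` share one core, while compound 3 `COc1cc(CN2C(=O)S/C(=C\c3ccc4[nH]c(-c5cc(OC)c(OC)c(OC)c5)nc4c3)C2=O)cc(OC)c1OC` and compound 4 `COc1ccc(-c2nc3cc(/C=C4\SC(=O)N(Cc5cc(OC)c(OC)c(OC)c5)C4=O)ccc3[nH]2)cc1OC` share another; how the two cores differ is not broken down here. In a functional assay on HeLa cells (Homo sapiens) for inhibition, read by MTT assay, with a stated time of 48 h (on this read-out lower numbers stand for stronger inhibition and higher numbers for weaker inhibition), compound 1 gives 1670 nM, and compound 2 gives 7830 nM. The change between them is hydrogen in place of methoxy on an aromatic carbon, and it produced a 4.7-fold higher number from compound 1 to compound 2 (0.67 log units; beyond the scatter). Compound 3 gives 2240 nM in this assay. Compound 4 differs from compound 3 by the same change, (hydrogen in place of methoxy on an aromatic carbon), made at the same place. Because compound 1 moved to compound 2 by a 4.7-fold higher number from compound 1 to compound 2 (0.67 log units; beyond the scatter), a step of similar size is expected here, namely a 4.0-fold higher number from compound 3 to compound 4 (0.60 log units; beyond the scatter). On that basis compound 4 is estimated to give about 9000 nM in this assay, with a likely range from 3500 nM to 25000 nM.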

Compound 4, half-maximal inhibitory concentration: 320 nM
Estimate against measurement, compound 4: 28-fold (1.45 log units) above; measured number below the stated range.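

On the core of compound 3, changing 3,4,5-trimethoxyphenyl to 3,4-dimethoxyphenyl gave a 7.0-fold lower number from compound 3 to compound 4 (0.85 log units; beyond the scatter) in this assay, the opposite direction to the step on the other core. The effect of this change therefore did not carry from one core to the other: the same change on two cores in this assay, a 4.7-fold higher number (0.67 log units; beyond the scatter) from compound 1 to compound 2 and a 7.0-fold lower number (0.85 log units; beyond the scatter) from compound 3 to compound 4, 33-fold (1.52 log units) apart, beyond the scatter of two such steps. This shows that the step seen on one core could not predict the step on the other, but two pairs cannot show which feature of the cores reverses the direction, or why.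

On these data alone, it remains open whether a hydroxyl or an amine in that place would follow either step. A third core would be needed to show how the change behaves more widely in the series.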